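Methoxy in Place of Methyl: What Compound 4 Should Give

The compounds below may be only part of what the source reports. "The series", "measured", "known", "first", "only" and "open" are said of these compounds alone.

Measured in a functional assay on MKN-45 cells (Homo sapiens) for cytotoxicity, read by MTT assay, with a stated time of 72 h; on this read-out higher numbers stand for weaker inhibition and lower numbers for stronger inhibition:
Compound 1, `COc1cc2c(Oc3ccc(NC(=O)c4cc(-c5ccc(F)cc5)ccn4)cc3F)ccnc2cc1OCCCN1CCCCC1`, gives 1240 nM.
Compound 2, `COc1cc2c(Oc3ccc(NC(=O)c4cc(-c5ccc(C(F)(F)F)cc5)ccn4)cc3F)ccnc2cc1OCCCN1CCCCC1`, gives 870 nM.
Compound 3, `COc1cc2c(Oc3ccc(NC(=O)c4cc(-c5ccc(C)cc5)ccn4)cc3F)ccnc2cc1OCCCN1CCCC1`, gives 440 nM.

Compound 3 shows the lowest number of the three. Its gap to compound 2 is within the scatter, so the two cannot be ordered; its gap to compound 1 is beyond the scatter. Going by the values given here, only one pair differs in a single place: compound 1 and compound 2, where a 1.4-fold lower number from compound 1 to compound 2 (0.15 log units; within the scatter), a change on the same six-membered ring that carries the group varied here. Compound 3 and compound 2 differ in two places at once, so their values can only be set side by side.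

Compound 4, `COc1ccc(-c2ccnc(C(=O)Nc3ccc(Oc4ccnc5cc(OCCCN6CCCC6)c(OC)cc45)c(F)c3)c2)cc1`, differs from compound 3 by methoxy in place of methyl on an aromatic carbon.

Among the compounds with values here, no measured step exchanges methyl for methoxy. Within the data shown here, the one step on that ring, from compound 1 to compound 2, stayed within the scatter, and that is the only guide. Compound 4 is therefore expected to sit close to compound 3 in this assay, with a step of a 1.0-fold higher number from compound 3 to compound 4 (0.01 log units; within the scatter), no change beyond the scatter. The estimate for compound 4 is 450 nM, with a range from 200 nM to 1000 nM.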

Compound 4, half-maximal inhibitory concentration: 150 nM
Estimate against measurement, compound 4: 3.0-fold (0.48 log units) above; the measured number lies below the stated range.
By their numbers in this assay, from the lowest: compound 4; then compounds 3, 2 and 1 (each within the scatter of the next, the first and the last beyond it).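

In this assay, going by these compounds alone, the exchange of 4-methylphenyl for 4-methoxyphenyl gives a 2.9-fold lower number from compound 3 to compound 4 (0.47 log units; beyond the scatter) and is the first single change on this ring to clear the scatter, which shows that the group on this aromatic carbon can shift the read-out. Within the data shown here, the only earlier step on this ring was a 1.4-fold lower number from compound 1 to compound 2 (0.15 log units; within the scatter) and stayed within the scatter, so the earlier compounds gave no sign that the choice of group here could matter, although that step was read with a different side chain on the core. Among these compounds, nothing available here explains why methoxy gives the lower number, and the single step does not separate the entering oxygen from the larger size of the group.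

The compounds shown leave open whether methoxy would give a similar step with the side chain carried by compound 1 and compound 2, since no pair tests that exchange there. They also leave open how this position would respond to a hydroxyl, an ethoxy group or a dimethylamino group on the same aromatic carbon.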